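Three aryl variants at a limit, and a dinitrophenyl next

The compounds below may be only part of what the source reports. "The series", "measured", "known", "first", "only" and "open" are said of these compounds alone.

In an ADME assay on L02 cells (Homo sapiens) for antiproliferative activity, read by MTT assay, with a stated time of 48 h (a higher number here means a weaker inhibitor, a lower number a stronger inhibitor), the three measured compounds stand as follows:

Compound 1 `N#CC1=C(N)Oc2c(N)cc3nc4ccccc4nc3c2C12C(=O)N(Cc1cnnn1-c1c(F)cccc1F)c1ccccc12` gives > 50000 nM.
Compound 2 `N#CC1=C(N)Oc2c(N)cc3nc4ccccc4nc3c2C12C(=O)N(Cc1cnnn1-c1ccc(Cl)cc1Cl)c1ccccc12` gives > 50000 nM.
Compound 3 `N#CC1=C(N)Oc2c(N)cc3nc4ccccc4nc3c2C12C(=O)N(Cc1cnnn1-c1ccc(F)c(Cl)c1)c1ccccc12` gives > 50000 nM.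

Compound 3 thus stands only at a limit of this assay, not at a number. The other two compounds sit at the same limit, as the limit of > 50000 nM in this assay, at which 3 of the 3 values shown sit, records. The steps among them, a step that the two limits leave unreadable from compound 1 to compound 2, a step that the two limits leave unreadable from compound 1 to compound 3 and a step that the two limits leave unreadable from compound 2 to compound 3, cannot be read in size or direction, since both ends of each are limits.

Compound 4 `N#CC1=C(N)Oc2c(N)cc3nc4ccccc4nc3c2C12C(=O)N(Cc1cnnn1-c1ccc([N+](=O)[O-])cc1[N+](=O)[O-])c1ccccc12` differs from compound 3 by 2,4-dinitrophenyl in place of 3-chloro-4-fluorophenyl on an aromatic nitrogen. The three measured steps bear on it only in that every aryl group tried on that aromatic nitrogen has left the compound at the limit; none gives a readable size. No step beyond the scatter can therefore be predicted in this assay.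

Compound 4 is consequently expected to remain at the limit as well, estimated at 50000 nM with a range of 20000 nM to 100000 nM. The implied step a number no higher from compound 3 to compound 4 (the limit leaves the size open) is expected to be nil within the scatter.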

Compound 4, half-maximal inhibitory concentration: 22800 nM
Beside the measured number, compound 4's estimate is 2.2-fold (0.34 log units) above it, within the range that was stated.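

In this assay, for the compounds shown here, the 2,4-dinitrophenyl group on this aromatic nitrogen gives the first readable number of the series, with compound 4 at 22800 nM. The change amounts to an at least 2.1-fold lower number from compound 3 to compound 4 (0.34 log units; beyond the scatter), and the same comparison gives an at least 2.1-fold lower number from compound 2 to compound 4 (0.34 log units; beyond the scatter) and an at least 2.1-fold lower number from compound 1 to compound 4 (0.34 log units; beyond the scatter). The aryl group at this place can therefore bring the result off the limit, which none of the chlorine- or fluorine-bearing aryl groups showed: the limit of > 50000 nM in this assay, at which 3 of the 4 values shown sit.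

From the compounds shown here alone, the full size of these steps stays open, as one end of each is a limit, and it is also unclear whether both nitro groups are needed. A phenyl group bearing a single nitro group, an amine or a carboxylic acid could show how far the number moves.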